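A few compounds are considered here, and "the series" means these few. Any claim that something is new, unique, unknown or untested is made for them only; others in the source may bear on it.

In a functional assay on MDA-MB-435 cells (Homo sapiens) for antiproliferative activity, read by sulforhodamine B assay, with a stated time of 48 h (a higher number here means a weaker inhibitor, a lower number a stronger inhibitor), compound 2 `COc1cc(-c2nn(-c3ccc(NC(=O)c4ccc(Cl)c(Cl)c4)cc3)cc2-c2ccncc2)ccc1Cl` gives 7130 nM, the higher of the two plain numbers shown. Compound 1 `COc1cc(-c2nn(-c3ccc(NC(=O)Nc4ccc(Cl)c(Cl)c4)cc3)cc2-c2ccncc2)ccc1Cl` gives 2870 nM, and the step of a 2.5-fold higher number from compound 1 to compound 2 (0.40 log units; beyond the scatter) is modest. Compound 3 `COc1cc(-c2nn(-c3ccc(NC(=O)c4cc(Cl)cc(Cl)c4)cc3)cc2-c2ccncc2)ccc1Cl` gives only a limit, > 100000 nM, which is the limit of > 100000 nM in this assay, at which 1 of the 3 values shown sits. Compound 4 `O=C(Nc1ccc(-n2cc(-c3ccncc3)c(-c3ccc(Cl)c(O)c3)n2)cc1)c1ccc(Cl)c(Cl)c1` differs from compound 2 by hydrogen in place of methyl on an oxygen on an aromatic ring. For the measured compounds named here, none of the measured steps touches this part of the molecule: an at least 34-fold higher number from compound 1 to compound 3 (1.54 log units; beyond the scatter) and an at least 14-fold higher number from compound 2 to compound 3 (1.14 log units; beyond the scatter) both concern the group on the carbonyl carbon, not the oxygen on the aromatic ring. With no comparison to guide it, the expectation for compound 4 in this assay is a step of a 1.0-fold lower number from compound 2 to compound 4 (0.01 log units; within the scatter), not beyond the scatter. Compound 4 is therefore estimated at 7000 nM, within a range from 2500 nM to 25000 nM.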

Compound 4, half-maximal inhibitory concentration: 2730 nM
Estimate against measurement, compound 4: 2.6-fold (0.41 log units) above; the range from low to high includes it.
By their numbers in this assay, from the lowest: compounds 4 and 1 (each within the scatter of the next); then compound 2. At a limit, above all of these: compound 3.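

In this assay, this is the first change shown away from the group on the carbonyl carbon, and replacing methoxy with hydroxy gives a 2.6-fold lower number from compound 2 to compound 4 (0.42 log units; beyond the scatter). The methyl on this oxygen is therefore not required for activity, and the position responds to even a one-carbon change. Nothing measured here accounts for this shift. Still open, as far as these compounds go, is how an amine or a longer chain such as ethoxy would behave at this position. Also open, from the compounds shown here alone, is whether hydroxy has the same effect alongside the (3,4-dichlorophenyl)amino group of compound 1.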